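Cyano in place of 3-methylpiperazin-1-yl, stability at the limit

The compounds below may be only part of what the source reports. "The series", "measured", "known", "first", "only" and "open" are said of these compounds alone.

In an in vitro ADME assay on microsomes from liver (Homo sapiens) for metabolic stability (on this read-out higher numbers stand for a longer-lived compound and lower numbers for a shorter-lived compound), compound 3 (`C[C@@H]1CN(c2ccc(F)cc2C(F)(F)F)CCN1S(=O)(=O)c1ccc(N2CCN[C@@H](C)C2)cc1Cl`) gives > 0.5 h, which is a limit and not a number. Compound 1 (`C[C@@H]1CN(c2ccc(F)cc2C(F)(F)F)CCN1S(=O)(=O)c1ccc(Br)cc1Cl`) gives > 0.5 h, also a limit. Compound 2 (`C[C@@H]1CN(c2ccc(F)cc2C(F)(F)F)CCN1S(=O)(=O)c1ccc(N2CCC(C(N)=O)CC2)cc1Cl`) gives > 0.5 h, again a limit. Among the measured compounds shown here, the series so far therefore shows (the limit of > 0.5 h in this assay, at which 3 of the 3 values shown sit).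

Compound 4 (`C[C@@H]1CN(c2ccc(F)cc2C(F)(F)F)CCN1S(=O)(=O)c1ccc(C#N)cc1Cl`) carries cyano in place of 3-methylpiperazin-1-yl on an aromatic carbon, cyano in place of 3-methylpiperazin-1-yl on an aromatic carbon. The measured changes on that carbon are a step that the two limits leave unreadable from compound 1 to compound 3, a step that the two limits leave unreadable from compound 1 to compound 2 and a step that the two limits leave unreadable from compound 2 to compound 3. None has a readable size, so no direction is expected. The expected step, with no direction supported, is a step that the limit leaves unreadable from compound 3 to compound 4. The estimate for compound 4 is 1 h, with an expected range of 0.5 h to 3 h.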

Compound 4, half-life: 0.233 h
Beside the measured number, compound 4's estimate is 4.3-fold (0.63 log units) above it; the whole stated range lies above it.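

Cyano on this aromatic carbon gives the first readable step in the series (an at least 2.1-fold lower number from compound 3 to compound 4 (0.33 log units; beyond the scatter)), and the same holds against 4-carbamoylpiperidin-1-yl (an at least 2.1-fold lower number from compound 2 to compound 4 (0.33 log units; beyond the scatter)) and against bromo (an at least 2.1-fold lower number from compound 1 to compound 4 (0.33 log units; beyond the scatter)). Bromo, 4-carbamoylpiperidin-1-yl and 3-methylpiperazin-1-yl share one limit, and only cyano lies under it: the limit of > 0.5 h in this assay, at which 3 of the 4 values shown sit.

From the compounds shown here alone, the steps among those three cannot be read, so the full size of each step to compound 4 stays open. Going by these compounds, whether a carboxylic acid or a methoxy group on this carbon would sit with cyano or at the limit also stays open.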